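Swapping Nitrile for Indolyl on the Pendant Phenyl

The compounds below may be only part of what the source reports. "The series", "measured", "known", "first", "only" and "open" are said of these compounds alone.

Compound 1 `CC1=C(C(=O)OCC2CCN(C(=O)OC(C)(C)C)CC2)C(c2cccc(C#N)c2)C2=C(CC(C)(C)CC2=O)N1` gives 220 nM in an assay on HEK293 cells for inhibition of neurogenic locus notch homolog protein 1 (Homo sapiens), read by a luciferase reporter and resazurin assay, with a stated time of 16 h (a higher number here means a weaker inhibitor, a lower number a stronger inhibitor), the lowest of the three numbers measured. Compound 2 `CC1=C(C(=O)OCC2CCN(C(=O)OC(C)(C)C)CC2)C(c2ccc3c(c2)OCCO3)C2=C(CC(C)(C)CC2=O)N1` gives 1520 nM and compound 3 `CC1=C(C(=O)OCC2CCN(C(=O)OC(C)(C)C)CC2)C(c2cc(Cl)cc(Cl)c2)C2=C(CC(C)(C)CC2=O)N1` gives 640 nM. Both steps away from compound 1 weakened inhibition: a 6.9-fold higher number from compound 1 to compound 2 (0.84 log units; beyond the scatter) and a 2.9-fold higher number from compound 1 to compound 3 (0.46 log units; beyond the scatter). Compound 4 `CC1=C(C(=O)OCC2CCN(C(=O)OC(C)(C)C)CC2)C(c2cccc(-c3ccc4[nH]ccc4c3)c2)C2=C(CC(C)(C)CC2=O)N1` differs from compound 1 in one place: 1H-indol-5-yl in place of cyano on an aromatic carbon. Within the data shown here, no measured step replaces the cyano with a bicyclic aromatic group, so the two steps from compound 1 are the only guide; both point to a weaker result, though neither resembles this change closely. The step is expected to be a 2.7-fold higher number from compound 1 to compound 4 (0.44 log units; beyond the scatter), a modest weakening. Compound 4 is estimated at 600 nM, with a range from 150 nM to 3000 nM.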

Compound 4, half-maximal inhibitory concentration: 770 nM
The estimate for compound 4 lay 1.3-fold (0.11 log units) below the measured number, and the stated range covers the measured number.
By their numbers in this assay, from the lowest: compound 1; then compounds 3, 4 and 2 (each within the scatter of the next, the first and the last beyond it).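

Unlike the earlier steps, which exchange the whole aryl group, this one changes only the group on an aromatic carbon of the pendant phenyl. In this assay the swap gives a 3.5-fold higher number from compound 1 to compound 4 (0.54 log units; beyond the scatter), so this carbon accepts 1H-indol-5-yl, with its two aromatic rings and hydrogen-bond donor, at a modest cost that still lies beyond the scatter. No evidence is available that bears on this step. On these data alone, whether the loss follows the added rings or the donor stays open, as does how an amine or a carboxylic acid on this carbon would compare with the nitrile of compound 1.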